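This account rests on a few compounds, and the source may have more. Where it says the series, first, only, none or still open, it means among the compounds named here.

Compound 3 `COc1ccc(-c2cnc(NC(=O)c3ccccc3)n2C)cc1` stands at the ceiling of a toxicity assay on THP-1 cells (Homo sapiens) for inhibition (on this read-out higher numbers stand for lower toxicity in this test and lower numbers for higher toxicity in this test), reaching only the limit of > 100000 nM. Compound 1 `COc1ccc(-c2cnc(NC(=O)c3ccccc3F)n2C)cc1` likewise stops at the limit in this assay with > 100000 nM. Compound 2 `COc1ccc(-c2cnc(NC(=O)CCc3ccccc3)n2C)cc1` also ends at the limit in this assay with > 100000 nM. Within the data shown here, because all three values sit at the limit of > 100000 nM in this assay, at which 3 of the 3 values shown sit, no step between them can be read: a step that the two limits leave unreadable from compound 1 to compound 3, a step that the two limits leave unreadable from compound 1 to compound 2 and a step that the two limits leave unreadable from compound 2 to compound 3. Compound 4 `COc1ccc(-c2cnc(NC(=O)c3cccc(F)c3)n2C)cc1` differs from compound 3 by fluoro in place of hydrogen on an aromatic carbon. Among the measured compounds shown here, the only step touching a fluoro on the same ring, from compound 1 to compound 3, is itself unreadable, so no direction can be drawn from it. Compound 4 is therefore expected to remain at the limit as well, with an estimated 150000 nM in this assay, between 50000 nM and 500000 nM, and an expected step that the limit leaves unreadable from compound 3 to compound 4.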

Compound 4, half-maximal cytotoxic concentration: > 100000 nM
Compound 4: no number, only a limit; the forecaster's own chance of this, stated with the estimate: 85%; the middle value does not contradict the limit.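

In this assay, among these compounds, compound 4 gives > 100000 nM, which is only a limit, so no step to it from compound 1, compound 2 or compound 3 can be read: the limit of > 100000 nM in this assay, at which 4 of the 4 values shown sit. The compounds shown leave open whether any change to this series would give a value inside the range of the assay.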